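The source may report more compounds than this note shows. Statements on the series, on what has been measured and on what is new or still open speak of the compounds shown alone.

Measured compounds:
- Compound 1, `CCC(CC)n1c(-c2ccc(OCc3c(-c4c(Cl)cccc4Cl)noc3C(C)C)cc2)nc2ccc(C(=O)O)cc21`, gives 5690 nM in an assay on HEK-293T cells for antagonist activity at vitamin D3 receptor (Homo sapiens), read by a luciferase reporter, with a stated time of 24 h; on this read-out higher numbers stand for weaker inhibition and lower numbers for stronger inhibition.
- Compound 2, `CC(C)c1onc(-c2c(Cl)cccc2Cl)c1COc1ccc(-c2nc3ccc(C(=O)O)cc3n2Cc2ccc(F)cc2)cc1`, gives 1140 nM in this assay.
- Compound 3, `CC(C)c1onc(-c2c(Cl)cccc2Cl)c1COc1ccc(-c2nc3ccc(C(=O)O)cc3n2CC(C)(C)C)cc1`, gives 861 nM in this assay.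

Compound 3 has the lowest of the three numbers, but its gap to compound 2, a 1.3-fold lower number from compound 2 to compound 3 (0.12 log units; within the scatter), lies within the scatter, so the two cannot be told apart; only compound 1 stands clearly apart, with a 6.6-fold lower number from compound 1 to compound 3 (0.82 log units; beyond the scatter).

Compound 4, `CCCn1c(-c2ccc(OCc3c(-c4c(Cl)cccc4Cl)noc3C(C)C)cc2)nc2ccc(C(=O)O)cc21`, is not yet measured. It differs from compound 3 in one place: ethyl in place of tert-butyl on a saturated chain carbon bound to an aromatic nitrogen. The measured steps that touch this part of the molecule are a 6.6-fold lower number from compound 1 to compound 3 (0.82 log units; beyond the scatter) and a 5.0-fold lower number from compound 1 to compound 2 (0.70 log units; beyond the scatter), both moves away from pentan-3-yl on the aromatic nitrogen that gave clearly lower numbers, and a 1.3-fold lower number from compound 2 to compound 3 (0.12 log units; within the scatter), which made no difference beyond the scatter. None of them tests a chain as short as propyl, so the direction of the new step is open. With the two unbranched groups already measured sitting close together, the expectation for compound 4 is a number near that of compound 3, with a lean towards a somewhat higher value, a step of a 1.7-fold higher number from compound 3 to compound 4 (0.24 log units; within the scatter). Compound 4 is therefore estimated at 1500 nM, between 500 nM and 5000 nM.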

Compound 4, half-maximal inhibitory concentration: 1400 nM
The estimate for compound 4 lay 1.1-fold (0.03 log units) above the measured number; the measured number falls inside the stated range.
By their numbers in this assay, from the lowest: compounds 3, 2 and 4 (each within the scatter of the next); then compound 1.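

In this assay, the change from neopentyl to propyl on the aromatic nitrogen gives a step that lies within the scatter (a 1.6-fold higher number from compound 3 to compound 4 (0.21 log units; within the scatter)), and so does the change from 4-fluorobenzyl to propyl (a 1.2-fold higher number from compound 2 to compound 4 (0.09 log units; within the scatter)), so a plain unbranched chain serves as well here as either of these two groups. Taking one ethyl off the saturated chain carbon bound to the aromatic nitrogen in pentan-3-yl, which leaves propyl, gives a step beyond the scatter (a 4.1-fold lower number from compound 1 to compound 4 (0.61 log units; beyond the scatter)), so among these four compounds only compound 1, the one with a branch on that carbon, stands apart, and no compound goes against this. Nothing shown here gives a measured reason for this pattern.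

From the compounds shown here alone, whether a smaller branch on that same carbon, as in isopropyl, would already separate from the propyl of compound 4 remains open, as does the effect of a ring such as cyclopentyl placed there. Also open, going by these compounds, is what a longer chain such as hexyl, or a chain ending in an amine or a hydroxyl group, would do on the aromatic nitrogen.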